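Relocating the Carboxy Group on the Terminal Phenyl Ring

The compounds below may be only part of what the source reports. "The series", "measured", "known", "first", "only" and "open" are said of these compounds alone.

Compound 1 `Cc1c(OCCCCOc2ccc(C(=O)O)cc2)ccc(C(=O)CC2CCCC2)c1O` gives 26.7% in an assay on HEK293 cells for positive allosteric modulation of metabotropic glutamate receptor 3 (Rattus norvegicus), read by thallium flux, with a stated time of 2.5 min; on this read-out lower numbers stand for smaller maximal responses and higher numbers for larger maximal responses.
Compound 2 `COC(=O)c1ccc(OCCCCOc2ccc(C(=O)CC3CCCC3)c(O)c2C)cc1` gives 22% in this assay.
Compound 3 `Cc1ccc(C(=O)O)cc1OCCCCOc1ccc(C(=O)CC2CCCC2)c(O)c1C` gives 26.9% in this assay.

Compound 3 holds the highest of the three numbers, yet its two neighbours sit within the scatter of it: a number 0.2 percentage points higher from compound 1 to compound 3 (within the scatter) and a number 4.9 percentage points higher from compound 2 to compound 3 (within the scatter). Compound 4 `Cc1cc(OCCCCOc2ccc(C(=O)CC3CCCC3)c(O)c2C)ccc1C(=O)O` differs from compound 3 only in the arrangement of the same atoms: 4-carboxy-3-methylphenyl in place of 5-carboxy-2-methylphenyl on an oxygen on a saturated carbon. Among the measured compounds shown here, the one measured step that exchanges the carboxy-bearing phenyl group at this oxygen, a number 0.2 percentage points higher from compound 1 to compound 3 (within the scatter), stayed within the scatter, as did the ester change a number 4.7 percentage points lower from compound 1 to compound 2 (within the scatter). For the measured compounds named here, no step moving the carboxy group around this ring has been measured. Compound 4 is therefore expected to show no step beyond the scatter, a number 0.9 percentage points lower from compound 3 to compound 4 (within the scatter). Compound 4 is estimated at 26%, between 16% and 36%.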

Compound 4, largest response reached (reported as percent of maximum), in percent of the reference or control that the assay uses: 23.7%
Beside the measured number, compound 4's estimate is 2.3 percentage points above it; the measured number falls inside the stated range.
By their numbers in this assay, from the lowest: compounds 2, 4, 1 and 3 (each within the scatter of the next).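

Exchanging 5-carboxy-2-methylphenyl for 4-carboxy-3-methylphenyl on the oxygen on a saturated carbon rearranges the same atoms and comes with a number 3.2 percentage points lower from compound 3 to compound 4 (within the scatter) in this assay, so this first change in the arrangement of the ring leaves the maximal response within the scatter. The other two new steps agree: a number 1.7 percentage points higher from compound 2 to compound 4 (within the scatter) with the ester exchanged for this group, and a number 3 percentage points lower from compound 1 to compound 4 (within the scatter) with methyl in place of hydrogen on an aromatic carbon. Nothing available explains these results. Still open, going by these compounds, is whether an amide or a tetrazole in place of the carboxy group, or a longer chain, would produce a step beyond the scatter.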